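Chloro in Place of Fluoro: an Expected Flat Step

The source may hold more compounds than are shown below. What is called first, only, known or untested is meant among the compounds shown, and "the series" means these compounds.

Of the compounds shown here, three have been measured in a functional assay on HT-29 cells (Homo sapiens) for cytotoxicity, read by MTT assay, with a stated time of 72 h; on this read-out lower numbers stand for higher toxicity in this test and higher numbers for lower toxicity in this test. Compound 1 `O=C(Nc1ccc([Se][Se]c2ccc(NC(=O)OCc3ccccc3)cc2)cc1)OCc1ccccc1` gives 69000 nM in this assay. Compound 3 `O=C(Nc1ccc([Se][Se]c2ccc(NC(=O)Oc3ccccc3)cc2)cc1)Oc1ccccc1` gives 70200 nM in this assay. Compound 2 `N#C[Se]c1ccc(NC(=O)Oc2ccc(F)cc2)cc1` gives 66500 nM in this assay, the lowest of the three numbers, but its gap to compound 1 and its gap to compound 3 both lie within the scatter of repeated measurements, so the three compounds stand at the same level on this read-out.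

Compound 4 `N#C[Se]c1ccc(NC(=O)Oc2ccc(Cl)cc2)cc1` has not yet been measured in this assay. It differs from compound 2 in one place: chloro in place of fluoro on an aromatic carbon. For the measured compounds named here, no pair among the measured compounds differs in a single place, so no measured step gives a direct guide to the size of this change. What the measured compounds do show is that far wider differences in structure leave the numbers within the scatter, because compound 1 gives 69000 nM and compound 3 gives 70200 nM while compound 2 gives 66500 nM. On that basis the step from fluoro to chloro is expected to be none beyond the scatter, in either direction, and the expected step is a 1.1-fold lower number from compound 2 to compound 4 (0.04 log units; within the scatter). Compound 4 is therefore estimated at 60000 nM in this assay, with an expected range from 25000 nM to 140000 nM.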

Compound 4, concentration lethal to 50% of the cells: 68700 nM
For compound 4 the middle estimate is 1.1-fold (0.06 log units) below the measured one; low and high end bracket the measured number.
By their numbers in this assay, from the lowest: compounds 2, 4, 1 and 3 (each within the scatter of the next).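

In this assay, for the compounds shown here, the change from fluoro to chloro on an aromatic carbon, para to a large group, now has a measured size of a 1.0-fold higher number from compound 2 to compound 4 (0.01 log units; within the scatter) and gives the series its first step that differs in one place only, which the earlier compounds could not supply. At this position, then, the read-out does not tell chloro from fluoro, and the flat step rests on a direct comparison rather than on compounds that differ widely in structure. Nothing available bears on why this step is so small.

From the compounds shown here alone, the pair speaks only for these two groups at this one place, so it remains open whether an amine, a carboxylic acid, a methoxy group or a longer chain in the same position would stay at this level or move the number beyond the scatter. Going by these compounds, it is equally open whether the change from fluoro to chloro would remain this flat at another place on the same ring or on the cores of compound 1 and compound 3.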